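Swapping Methyl for Cyclopropyl on the Aromatic Ring

The source may hold more compounds than are shown below. What is called first, only, known or untested is meant among the compounds shown, and "the series" means these compounds.

Among the compounds with values here, compound 1 `COC(=O)Nc1cc(-c2ccc(OC[C@@](C)(N)CC(C)C)c(C)c2)ccn1` gives the lowest of the two numbers measured so far in an assay on isolated protein for inhibition of AP2-associated protein kinase 1 (Homo sapiens), with a stated time of 3 h, in the presence of a further agent that is not named here (a lower number here means a stronger inhibitor, a higher number a weaker inhibitor), where compound 1 reaches 0.8 nM. Its nearest neighbour is compound 2 `COC(=O)Nc1cc(-c2ccc(OC[C@@](C)(N)CC(C)C)c(C)c2C)ccn1`, which carries one additional methyl on an aromatic carbon and in this assay gives 4.5 nM. The measured step of a 5.6-fold higher number from compound 1 to compound 2 (0.75 log units; beyond the scatter) shows that growing this ring by a small carbon group can weaken inhibition. Compound 3 `COC(=O)Nc1cc(-c2ccc(OC[C@@](C)(N)CC(C)C)c(C3CC3)c2)ccn1` differs from compound 1 in one place: cyclopropyl in place of methyl on an aromatic carbon. Within the data shown here, no measured step covers this exact exchange, so the only guide is the weakening seen in a 5.6-fold higher number from compound 1 to compound 2 (0.75 log units; beyond the scatter), which also enlarged the carbon substitution on the same ring. A weakening of similar or smaller size is therefore expected, giving the estimated step of a 2.5-fold higher number from compound 1 to compound 3 (0.40 log units; beyond the scatter). Compound 3 is thus expected to give about 2 nM in this assay, most likely between 0.7 nM and 6 nM.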

Compound 3, half-maximal inhibitory concentration: 0.4 nM
Beside the measured number, compound 3's estimate is 5.0-fold (0.70 log units) above it; the whole stated range lies above it.
By their numbers in this assay, from the lowest: compounds 3 and 1 (each within the scatter of the next); then compound 2.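

At the aromatic carbon ortho to the (2-amino-2,4-dimethylpentyl)oxy group, this assay accepts a cyclopropyl ring in place of methyl, with three heavy atoms where there was one: the change gives a 2.0-fold lower number from compound 1 to compound 3 (0.30 log units; within the scatter), so compounds 1 and 3 cannot be told apart here. The weakening seen with the extra ring methyl, a 5.6-fold higher number from compound 1 to compound 2 (0.75 log units; beyond the scatter), therefore does not hold for every added carbon on this ring, and compound 3 goes against any such rule. Nothing measured here bears on the reason for this result.

The compounds shown leave open how much larger a carbon group this position accepts, for example isopropyl, tert-butyl or cyclobutyl. They also leave open whether a group containing other atoms, such as methoxy or an amine, would fit the same place.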